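The compounds below may be only part of what the source reports. "The series", "measured", "known", "first", "only" and "open" are said of these compounds alone.

In an ADME assay on HEK293 cells (Homo sapiens) for cytotoxicity, read by CCK-8 assay, with a stated time of 48 h (on this read-out lower numbers stand for stronger inhibition and higher numbers for weaker inhibition), compound 1 `COc1ccc(/C=C\c2cc(OC)c(OC)c(OC)c2)cc1OCc1ccc(C=O)cc1`, which carries a formyl group, gives 46000 nM. Compound 2 `COc1ccc(/C=C\c2cc(OC)c(OC)c(OC)c2)cc1OCc1ccc(CN[C@H](C(=O)O)[C@H](C)O)cc1` returns only a limit, > 50000 nM. Compound 3 `COc1ccc(/C=C\c2cc(OC)c(OC)c(OC)c2)cc1OCc1ccc(CN2CC[C@H](O)C2)cc1` also returns only a limit, > 50000 nM. Compound 3 thus stands with compound 2 at the limit of > 50000 nM in this assay, at which 2 of the 3 values shown sit.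

Compound 4 `COc1ccc(/C=C\c2cc(OC)c(OC)c(OC)c2)cc1OCc1ccc(CN2CC[C@@H](O)C2)cc1` changes one feature of compound 3: the two compounds have the same atoms and bonds and differ only in configuration as drawn: 1 of 2 stereo elements differ; a stereocentre at a saturated ring carbon is drawn S in compound 3 and R in compound 4. A stereocentre at a saturated ring carbon is drawn S in compound 3 and R in compound 4.

For the measured compounds named here, no measured step changes configuration alone. The nearest are an at least 1.0-fold higher number from compound 1 to compound 3 (0.03 log units; that floor lies within the scatter) and an at least 1.0-fold higher number from compound 1 to compound 2 (0.03 log units; that floor lies within the scatter), both floors within the scatter, while a step that the two limits leave unreadable from compound 2 to compound 3 cannot be read. The expected change is therefore no more than scatter: a step that the limit leaves unreadable from compound 3 to compound 4. For compound 4 the estimated value is 55000 nM, with an expected range from 30000 nM to 100000 nM.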

Compound 4, half-maximal inhibitory concentration: > 50000 nM
Compound 4: no number, only a limit; the forecaster's own chance of this, stated with the estimate: 80%; the middle value lies beyond the limit too.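

In this assay compound 4 returns only a limit, and so the steps from compound 2 and from compound 3 to it cannot be read. For the compounds shown here, the one readable step is an at least 1.0-fold higher number from compound 1 to compound 4 (0.03 log units; that floor lies within the scatter). What is new is that both drawn configurations at the saturated ring carbon of the 3-hydroxypyrrolidin-1-yl group now sit at the same limit: the limit of > 50000 nM in this assay, at which 3 of the 4 values shown sit.

On these data alone, how far past that limit compound 3 and compound 4 each lie remains open. So does whether a dimethylamino group in place of 3-hydroxypyrrolidin-1-yl would also stay at the limit.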